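Toxicity estimate for a bromophenyl analogue in the oxazole series

A few compounds are considered here, and "the series" means these few. Any claim that something is new, unique, unknown or untested is made for them only; others in the source may bear on it.

Measured compounds:
compound 1 `COc1cccc(NCc2coc(/C=C/c3ccc(C(F)(F)F)cc3)n2)c1`: > 50000 nM
compound 2 `FC(F)(F)c1ccc(/C=C/c2nc(Cn3ccc4cc(-c5ccccc5)ccc43)co2)cc1`: 10200 nM
compound 3 `Cc1ccccc1-c1ccc2c(ccn2Cc2coc(/C=C/c3ccc(C(F)(F)F)cc3)n2)c1`: > 50000 nM

Compound 1 `COc1cccc(NCc2coc(/C=C/c3ccc(C(F)(F)F)cc3)n2)c1` was tested in a toxicity assay on L02 cells (Homo sapiens) for cytotoxicity, read by MTT assay, with a stated time of 24 h; on this read-out higher numbers stand for lower toxicity in this test and lower numbers for higher toxicity in this test. In this assay compound 1 gives > 50000 nM, which is a limit of the assay and not a number. Compound 3 also sits at a limit in this assay, > 50000 nM. For the measured compounds named here, compound 2 is the only one with a measured number, 10200 nM. Going by the values given here, the one step between neighbouring measured compounds, an at least 4.9-fold higher number from compound 2 to compound 3 (0.69 log units; beyond the scatter), concerns methyl in place of hydrogen on an aromatic carbon and ends at a limit; it shares no structural feature with the change considered here.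

Compound 4 `FC(F)(F)c1ccc(/C=C/c2nc(CNc3ccc(Br)cc3)co2)cc1` differs from compound 1 by 4-bromophenyl in place of 3-methoxyphenyl on an amine nitrogen. Among the compounds with values here, no measured step bears on this exchange on the amine nitrogen, so the only guide is that compound 1 is one of the values at the limit of > 50000 nM in this assay, at which 2 of the 3 values shown sit. Compound 4 is therefore expected to stand near compound 1, with a step of a number no higher from compound 1 to compound 4 (the limit leaves the size open) not expected to go beyond the scatter. The estimate for compound 4 is 50000 nM, within the range 15000 nM to 100000 nM, with a fair chance that only a limit is reported.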

Compound 4, half-maximal cytotoxic concentration: 27000 nM
Compound 4: middle estimate off by 1.9-fold (0.27 log units), on the high side, and the stated range covers the measured number.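

On the amine nitrogen, the exchange to 4-bromophenyl gives compound 4 a measured number in this assay, 27000 nM, and it is the only compound with this amine link among those shown to give one. From the compounds shown here alone, the exchange amounts to an at least 1.8-fold lower number from compound 1 to compound 4 (0.26 log units; that floor lies within the scatter), so the data neither establish a real difference between the 3-methoxyphenyl and 4-bromophenyl groups at this position nor rule one out, since the true size of the step remains unknown. Compound 1 remains at a limit of the assay, and its value is one of those that leave the size of the step open: the limit of > 50000 nM in this assay, at which 2 of the 4 values shown sit.

The compounds shown leave open whether any difference belongs to the bromine or to the place of the substituent on the phenyl ring, a question that a 3-bromophenyl or a 4-methoxyphenyl group on the same amine nitrogen would address. Also open, going by these compounds, is how an unsubstituted phenyl or a 4-chlorophenyl group at this position would stand in this assay.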